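The source may report more compounds than this note shows. Statements on the series, on what has been measured and on what is new or still open speak of the compounds shown alone.

Measured compounds in the series:

compound 1, `Cc1ccc(S(=O)(=O)N/C(=N\O)Nc2ccc(Cl)cc2)cc1`: 49 ug/mL
compound 2, `Cc1ccc(S(=O)(=O)N/C(=N\O)Nc2ccc(Cl)c(Cl)c2)cc1`: 72 ug/mL
compound 3, `Cc1ccc(S(=O)(=O)/N=C(\S)Nc2ccc(Cl)cc2)cc1`: 232 ug/mL

Compound 4, `Cc1ccc(S(=O)(=O)/N=C(\S)Nc2ccc(Cl)c(Cl)c2)cc1`, is not yet measured.

In a functional assay on HepG2 cells (Homo sapiens) for cytotoxicity (on this read-out higher numbers stand for weaker inhibition and lower numbers for stronger inhibition), compound 1 gives 49 ug/mL. Compound 2 carries chloro in place of hydrogen on an aromatic carbon, and the step is a 1.5-fold higher number from compound 1 to compound 2 (0.17 log units; within the scatter). Compound 3 has a different core from compound 1; the difference between the two cores is not broken down here. In this assay compound 3 gives 232 ug/mL, the highest of the three numbers, and its distance to compound 2 and to compound 1 lies beyond the scatter.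

Compound 4 carries chloro in place of hydrogen on an aromatic carbon; the place is described in the same words as for the earlier step, so this is the same change on the other core. Among the measured compounds shown here, the expectation is a step of about a 1.3-fold higher number from compound 3 to compound 4 (0.11 log units; within the scatter), that is, a step of the same small size as a 1.5-fold higher number from compound 1 to compound 2 (0.17 log units; within the scatter), since the single precedent for this change stayed within the scatter. Compound 4 is therefore estimated at 300 ug/mL, with a range from 150 ug/mL to 600 ug/mL, the width allowing for the possibility that the change behaves differently on the core of compound 3.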

Compound 4, half-maximal inhibitory concentration: 120 ug/mL
The estimate for compound 4 lay 2.5-fold (0.40 log units) above the measured number; measured number below the stated range.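

In this assay the added chloro gives a 1.9-fold lower number from compound 3 to compound 4 (0.29 log units; within the scatter), a step within the scatter, as was the step on the core of compound 1. Neither step departs from the scatter alone, yet the two do not agree with each other, so the step seen on one core cannot be taken as a fixed number for the other: the same change on two cores in this assay, a 1.5-fold higher number (0.17 log units; within the scatter) from compound 1 to compound 2 and a 1.9-fold lower number (0.29 log units; within the scatter) from compound 3 to compound 4, 2.8-fold (0.45 log units) apart, beyond the scatter of two such steps. Among the compounds shown here, this rests on a single pair per core, so it shows only that the change did not carry over unchanged between these two cores, and it shows neither the reason for the gap nor how the change would behave on any further core.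

The compounds shown leave open whether the same gap would appear with another group in this place, such as fluoro, methoxy or an amine. They also leave open whether a pair with a carboxylic acid or a longer chain on the same aromatic ring would give matching steps on the two cores.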